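The source may hold more compounds than are shown below. What is called first, only, known or untested is meant among the compounds shown, and "the series" means these compounds.

Measured in a functional assay on FM3A cells (Mus musculus) for antiproliferative activity, read by cell counting, with a stated time of 2 days; a lower number here means a stronger inhibitor, a higher number a weaker inhibitor:
- compound 1 `COc1cc(C(=O)c2sc(N3CCCCC3)nc2N)cc(OC)c1OC`: 39000 nM
- compound 2 `COc1ccc(C(=O)c2sc(N3CCCC3)nc2N)cc1OC`: 112000 nM
- compound 3 `COc1ccc(C(=O)c2sc(N3CCCC3)nc2N)cc1`: > 200000 nM

Compound 3 gives only a limit of the assay, > 200000 nM, and not a number. This is the limit of > 200000 nM in this assay, at which 1 of the 3 values shown sits.

Compound 4 `Nc1nc(N2CCCC2)sc1C(=O)c1ccc(Br)cc1` carries bromo in place of methoxy on an aromatic carbon, para to a large group: bromo in place of methoxy on an aromatic carbon.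

Among the compounds with values here, one measured step bears on this change, and it also replaces a methoxy on an aromatic carbon, though with hydrogen: an at least 1.7-fold higher number from compound 2 to compound 3 (0.25 log units; that floor lies within the scatter). That small, open-ended step gives no reason to expect a clear move in either direction in this assay, so no change beyond the scatter is expected.

The expected step is a number no higher from compound 3 to compound 4 (the limit leaves the size open).

The estimate for compound 4 is 200000 nM, with an expected range from 90000 nM to 400000 nM.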

Compound 4, half-maximal inhibitory concentration: > 200000 nM
Compound 4: a limit, no number; the forecaster's own chance of this, stated with the estimate: 55%; the middle value lies on the limit itself.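

Compound 3 and compound 4 both give only a limit of the assay, so no step between them can be read: the limit of > 200000 nM in this assay, at which 2 of the 4 values shown sit.

As far as these compounds go, whether bromo or methoxy gives the stronger inhibitor in this assay stays open.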